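Swapping a Ring for a Fluorinated Ether on the Shared Core

The source may report more compounds than this note shows. Statements on the series, on what has been measured and on what is new or still open speak of the compounds shown alone.

Of the compounds shown here, two with the same core have been measured in a physicochemical assay for solubility, measured as kinetic solubility; a higher number here means a more soluble compound, a lower number a less soluble compound. Compound 1 `CC(C)n1nc(C(N)=O)cc1-c1ccc(N(C)C(=O)c2c(F)cccc2Cl)c(OCC(F)(F)F)c1` gives 32 ug/mL. Compound 2 `CC(=O)Nc1cc(-c2ccc(N(C)C(=O)c3c(F)cccc3Cl)c(N3CCCC3)c2)n(C(C)C)n1` gives 12 ug/mL, the lower of the two numbers, and its gap to compound 1 lies beyond the scatter. Compound 3 `CC(=O)Nc1cc(-c2ccc(N(C)C(=O)c3c(F)cccc3Cl)c(OCC(F)(F)F)c2)n(C(C)C)n1` has not been measured yet. The change from compound 2 to compound 3 is 2,2,2-trifluoroethoxy in place of pyrrolidin-1-yl on an aromatic carbon. Among the compounds with values here, no step between two measured compounds isolates this change, so the expectation rests on the numbers as they stand. Compound 1, which also carries the 2,2,2-trifluoroethoxy group, sits higher with its value of 32 ug/mL, so a modest rise is expected, of about a 2.1-fold higher number from compound 2 to compound 3 (0.32 log units; beyond the scatter), a step that only just reaches beyond the scatter. For compound 3 the estimated value in this assay is therefore 25 ug/mL, with a likely range from 9 ug/mL to 70 ug/mL.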

Compound 3, solubility: 27 ug/mL
Compound 3: middle estimate off by 1.1-fold (0.03 log units), on the low side; the range from low to high includes it.
By their numbers in this assay, from the lowest: compound 2; then compounds 3 and 1 (each within the scatter of the next).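

In this assay the swap of pyrrolidin-1-yl for 2,2,2-trifluoroethoxy on this aromatic carbon, now seen with the rest of the molecule held constant, gives a 2.3-fold higher number from compound 2 to compound 3 (0.35 log units; beyond the scatter) and so shows that the group at this position alone shifts the reading by a modest step. The other change, acetamido in place of carbamoyl on an aromatic carbon, gives a 1.2-fold lower number from compound 1 to compound 3 (0.07 log units; within the scatter) and so leaves the two compounds carrying 2,2,2-trifluoroethoxy indistinguishable in this measurement. Nothing measured here explains either step.

On these data alone, it stays open whether a morpholine ring, a methoxy group or an open-chain dimethylamino group at this position would read closer to pyrrolidin-1-yl or to 2,2,2-trifluoroethoxy. As far as these compounds go, it also stays open whether the step at this position would be the same size with carbamoyl in place of acetamido.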